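This account rests on a few compounds, and the source may have more. Where it says the series, first, only, none or still open, it means among the compounds named here.

Within the data shown here, compound 1 `CCCOC(=O)OCC(CO)CCn1cnc2cnc(N)nc21` is the shorter-lived of the two compounds measured so far. Among the measured compounds shown here, in an ADME assay for pharmacokinetics, read by HPLC, in phosphate buffer, at 37 degrees C, at pH 8 (on this read-out higher numbers stand for a longer-lived compound and lower numbers for a shorter-lived compound), compound 1 gives 96 h, the lowest of the two numbers known. Compound 2 `CC(C)OC(=O)OCC(CO)CCn1cnc2cnc(N)nc21` gives 624 h, which amounts to a 6.5-fold higher number from compound 1 to compound 2 (0.81 log units; beyond the scatter). Compound 3 `CCOC(=O)OCC(CO)CCn1cnc2cnc(N)nc21` differs from compound 1 by hydrogen in place of methyl on a saturated chain carbon, two bonds along the chain from an oxygen next to a carbonyl group. For the measured compounds named here, the one measured step concerns branching of the chain rather than its length, so it bears only loosely on this change. Going by the values given here, with no step of the same kind measured, the change expected from compound 1 to compound 3 is a 1.4-fold lower number from compound 1 to compound 3 (0.14 log units; within the scatter), within the scatter. Compound 3 is therefore estimated at 70 h, between 30 h and 200 h.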

Compound 3, half-life: 72 h
The estimate for compound 3 lay 1.0-fold (0.01 log units) below the measured number, within the range that was stated.
By their numbers in this assay, from the lowest: compounds 3 and 1 (each within the scatter of the next); then compound 2.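

In this assay, going from propyl to ethyl gives a 1.3-fold lower number from compound 1 to compound 3 (0.12 log units; within the scatter), so this shortening of the straight chain on the carbonate oxygen does not separate the two compounds. Setting ethyl against the branched isopropyl gives an 8.7-fold lower number from compound 2 to compound 3 (0.94 log units; beyond the scatter), so among these three compounds only the isopropyl compound stands apart. No supporting measurement offers an explanation for this pattern. The compounds shown leave open whether a longer straight chain such as butyl would match propyl and ethyl. They also leave open whether a tert-butyl or cyclopropyl group would match isopropyl.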